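Taking one methoxy off compound 3

This account rests on a few compounds, and the source may have more. Where it says the series, first, only, none or still open, it means among the compounds named here.

Within the data shown here, in a functional assay on PC-3 cells (Homo sapiens) for inhibition, read by sulforhodamine B assay, with a stated time of 48 h, tested at 50 uM (on this read-out lower numbers stand for less inhibition of growth and higher numbers for more inhibition of growth at the one concentration tested), the series so far gives modest numbers at best. Compound 1 `COc1cccc(/C=C/C(=O)/C=C/c2ccc(OCc3cn(CCCCCOc4cc(=O)oc5ccccc45)nn3)c(OC)c2)c1` is recorded as "not active" (no number reported), with no number attached. Compound 2 `COc1cccc(/C=C/C(=O)/C=C/c2ccc(OCc3cn(CCOc4cc(=O)oc5ccccc45)nn3)c(OC)c2)c1` gives 13%. Compound 3 `COc1ccc(/C=C/C(=O)/C=C/c2ccc(OCc3cn(CCOc4cc(=O)oc5ccccc45)nn3)c(OC)c2)cc1OC` gives 19%, and so stands level with compound 2 within the scatter, with a number 6 percentage points higher from compound 2 to compound 3 (within the scatter).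

Compound 4 `COc1ccc(/C=C/C(=O)/C=C/c2ccc(OCc3cn(CCOc4cc(=O)oc5ccccc45)nn3)c(OC)c2)cc1` has not yet been measured in this assay. Its structure follows from compound 3 by hydrogen in place of methoxy on an aromatic carbon, on a ring of carbon only, so that 3,4-dimethoxyphenyl becomes 4-methoxyphenyl: hydrogen in place of methoxy on an aromatic carbon.

Among the measured compounds shown here, one measured step bears on this change, and it is the same kind of exchange run the other way: methoxy in place of hydrogen on an aromatic carbon, with a number 6 percentage points higher from compound 2 to compound 3 (within the scatter). For the measured compounds named here, no measured step removes this particular methoxy group, so that evidence is thin. The expectation for this assay is therefore a small drop at most and no real change beyond the scatter, with the estimated step being a number 4 percentage points lower from compound 3 to compound 4 (within the scatter). A report of no activity, as for compound 1, cannot be ruled out.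

For compound 4 the estimated value is 15%, with an expected range of 5% to 27%.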

Compound 4, percent growth inhibition at one concentration: 15%
The estimate for compound 4 equals the measured number at the digits printed, and the stated range covers the measured number.
By their numbers in this assay, from the lowest: compounds 2, 4 and 3 (each within the scatter of the next).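

In this assay, taking the methoxy off the 3,4-dimethoxyphenyl ring to leave 4-methoxyphenyl gives a number 4 percentage points lower from compound 3 to compound 4 (within the scatter), so this exchange, now read in the removing direction, also stays inside the scatter. Among these compounds, the new compound also gives the first reading on where a single methoxy sits on this ring: 4-methoxyphenyl in place of 3-methoxyphenyl gives a number 2 percentage points higher from compound 2 to compound 4 (within the scatter), so neither the place of that methoxy nor the presence of a second one separates these three compounds. No measured information on any cause accompanies these small steps.

Open, as far as these compounds go, is whether a hydroxy group, an amine or a carboxylic acid on this ring, or a ring with no methoxy at all, would give a number beyond the scatter of these three compounds. The single tested concentration also leaves open how compounds 2, 3 and 4 would read at other concentrations in this assay.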